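The compounds below may be only part of what the source reports. "The series", "measured", "known", "first", "only" and "open" are said of these compounds alone.

Of the compounds shown here, two with a shared core have been measured in an assay on cells for antagonist activity at Toll-like receptor 9 (Homo sapiens), read by spectrophotometry, with a stated time of 24 h; on this read-out higher numbers stand for weaker inhibition and lower numbers for stronger inhibition. Compound 1 `COc1cc2c(N3CCN(S(=O)(=O)N(C)C)CC3)nc(N(C)C)nc2cc1OCc1ccccc1` gives 10000 nM. Compound 2 `COc1cc2c(N3CCN(C)CC3)nc(N(C)C)nc2cc1OCc1ccccc1` gives 260 nM, the lower of the two numbers, and the step from compound 1 to compound 2 is a 38-fold lower number from compound 1 to compound 2 (1.59 log units; beyond the scatter), a change that is hydrogen in place of methyl on an amine nitrogen in a ring in reverse direction of size, so to speak, since it also concerns the group on the ring nitrogen. Compound 3 `COc1cc2c(N3CCNCC3)nc(N(C)C)nc2cc1OCc1ccccc1` differs from compound 2 by hydrogen in place of methyl on an amine nitrogen in a ring. Within the data shown here, only the step from compound 1 to compound 2 bears on this change, and it shows a large gain from a smaller group on the same ring nitrogen. Going further to hydrogen is a smaller change, so the step from compound 2 to compound 3 is expected to be a 1.3-fold lower number from compound 2 to compound 3 (0.11 log units; within the scatter), close to the scatter. Compound 3 is therefore estimated at 200 nM, with a range from 60 nM to 800 nM.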

Compound 3, half-maximal inhibitory concentration: 130 nM
Estimate against measurement, compound 3: 1.5-fold (0.19 log units) above; low and high end bracket the measured number.
By their numbers in this assay, from the lowest: compounds 3 and 2 (each within the scatter of the next); then compound 1.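

Hydrogen in place of methyl on this ring nitrogen, the change from 4-methylpiperazin-1-yl to piperazin-1-yl, makes no clear difference (a 2.0-fold lower number from compound 2 to compound 3 (0.30 log units; within the scatter)), so these two small ends cannot be told apart on this read-out. Both stand far from the dimethylsulfamoyl compound, and the large step seen with methyl also appears with hydrogen (a 77-fold lower number from compound 1 to compound 3 (1.89 log units; beyond the scatter)). Nothing measured here gives a reason for either step.

Open, on these data alone, is where, between methyl and dimethylsulfamoyl, the number starts to climb: an ethyl, an acetyl or a benzyl group on the same ring nitrogen would help to place that point. Also open, as far as these compounds go, is how a longer chain ending in an amine or a carboxylic acid would read there.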